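From a Hydroxypropynyl Arm to a Plain Hydroxy Group

The source may report more compounds than this note shows. Statements on the series, on what has been measured and on what is new or still open speak of the compounds shown alone.

In an ADME assay on L1210/0 cells (Mus musculus) for cytotoxicity, with a stated time of 48 h (on this read-out higher numbers stand for weaker inhibition and lower numbers for stronger inhibition), compound 1 `O=c1[nH]c(=O)n([C@H]2C[C@H](O)[C@@H](CO)O2)cc1C#CCO` gives > 200000 nM, which is a limit of the assay rather than a number. Compound 1 therefore stands at the limit of > 200000 nM in this assay, at which 3 of the 3 values shown sit. Compound 2 `CC(=O)OCCOCn1cnc2c(Cl)nc(N)nc21` gives > 200000 nM in this assay, again a limit. Compound 3 `Nc1nc2c(nc(Br)n2COCCO)c(=O)[nH]1` gives > 200000 nM in this assay, also a limit. Among the compounds with values here, no step between two measured compounds is available, so the measured numbers say nothing about how large a change of this kind might be.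

Compound 4 `O=c1[nH]c(=O)n([C@H]2C[C@H](O)[C@@H](CO)O2)cc1O` differs from compound 1 in one place: hydroxy in place of 3-hydroxyprop-1-yn-1-yl on an aromatic carbon. Since compound 1 sits at the limit of > 200000 nM in this assay, at which 3 of the 3 values shown sit, the step the account expects in this assay is a number no higher from compound 1 to compound 4 (the limit leaves the size open), that is, no step beyond the scatter in either direction. For compound 4 the expected value in this assay is 200000 nM, within a range from 50000 nM to 800000 nM, and it is expected to be reported again as a limit rather than a number.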

Compound 4, half-maximal inhibitory concentration: > 200000 nM
Compound 4: only a limit was reported; the forecaster's own chance of this, stated with the estimate: 80%; the middle value lies on the limit itself.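

Within the data shown here, compound 1 and compound 4 are both reported only as limits in this assay, so no step between them can be read. The compounds shown leave open whether hydroxy in place of 3-hydroxyprop-1-yn-1-yl changes the read-out at all: the limit of > 200000 nM in this assay, at which 4 of the 4 values shown sit.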